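A few compounds are considered here, and "the series" means these few. Any claim that something is new, unique, unknown or untested is made for them only; others in the source may bear on it.

Compound 2 `CC1CCN(c2c(S(=O)(=O)c3cc(Cl)cc(Cl)c3)cnc3cc(Cl)ccc23)CC1` was tested in an assay on isolated protein for displacement of a labelled ligand from metabotropic glutamate receptor 5 (Homo sapiens), with a stated time of 60 min, tested at 1 uM (on this read-out higher numbers stand for more inhibition at the one concentration tested (going by the name of the read-out) and lower numbers for less inhibition), and gave 93%. Among the measured compounds shown here, only one other compound has been measured: compound 1 `CC1CCN(c2c(S(=O)(=O)c3ccc(Cl)cc3)cnc3cc(Cl)ccc23)CC1`, which in this assay gave 91%. Both numbers are high, and the step of a number 2 percentage points higher from compound 1 to compound 2 (within the scatter) is within the usual scatter, so the two compounds cannot be told apart on this read-out. Compound 3 `Cc1ccc(S(=O)(=O)c2cnc3cc(Cl)ccc3c2N2CCC(C)CC2)cc1` has not yet been measured. It differs from compound 2 in the group on the sulfonyl sulfur, the same place where compound 1 and compound 2 differ: 4-methylphenyl in place of 3,5-dichlorophenyl on a sulfonyl sulfur. For the measured compounds named here, the one measured step at this place, a number 2 percentage points higher from compound 1 to compound 2 (within the scatter), did not move the number beyond the scatter, although it exchanged 4-chlorophenyl for 3,5-dichlorophenyl rather than bringing in 4-methylphenyl. On that single precedent the expected step of a number 8 percentage points lower from compound 2 to compound 3 (within the scatter) is small, with no clear direction. Compound 3 is therefore estimated to give 85%, within a range from 65% to 97%.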

Compound 3, a percentage reported as inhibition, at one concentration (the size of the read-out at that concentration, not a potency): 94%
The estimate for compound 3 lay 9 percentage points below the measured number; measured number inside the range.
By their numbers in this assay, from the lowest: compounds 1, 2 and 3 (each within the scatter of the next).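

With the sulfonyl sulfur as the place of change, 4-methylphenyl and 3,5-dichlorophenyl cannot be told apart in this assay (a number 1 percentage points higher from compound 2 to compound 3 (within the scatter)). Methyl in place of chloro on an aromatic carbon also leaves the two compounds indistinguishable (a number 3 percentage points higher from compound 1 to compound 3 (within the scatter)), so among these three compounds, chlorine on the group at this position is not required for a high number. No measurement here offers an explanation for this sameness.

All three numbers sit high at a single concentration, so any differences in potency among these compounds remain unresolved. From the compounds shown here alone, it also remains open whether the number stays this high with a phenyl ring carrying an amine or a carboxylic acid, or with a non-aromatic group such as cyclohexyl on the sulfonyl sulfur.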